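The source may report more compounds than this note shows. Statements on the series, on what has been measured and on what is new or still open speak of the compounds shown alone.

In a functional assay on HepG2 cells (Homo sapiens) for antiproliferative activity, read by MTT assay, with a stated time of 48 h (on this read-out higher numbers stand for weaker inhibition and lower numbers for stronger inhibition), compound 3 `CC(=O)Nc1ccc(-n2nncc2CN2C(=O)C3(C(C#N)=C(N)Oc4c3c3nc5ccccc5nc3c3ccccc43)c3ccccc32)cc1` gives only the limit of the assay, > 50000 nM. Compound 1 `N#CC1=C(N)Oc2c(c3nc4ccccc4nc3c3ccccc23)C12C(=O)N(Cc1cnnn1-c1cccc(Cl)c1)c1ccccc12`, carrying 3-chlorophenyl on the same aromatic nitrogen, also gives only a limit in this assay, > 50000 nM. Compound 2 `CCOc1ccc(-n2nncc2CN2C(=O)C3(C(C#N)=C(N)Oc4c3c3nc5ccccc5nc3c3ccccc43)c3ccccc32)cc1`, with 4-ethoxyphenyl there, likewise returns a limit in this assay, > 50000 nM. The three steps among them are therefore not readable: a step that the two limits leave unreadable from compound 1 to compound 2, a step that the two limits leave unreadable from compound 1 to compound 3 and a step that the two limits leave unreadable from compound 2 to compound 3, all because of the limit of > 50000 nM in this assay, at which 3 of the 3 values shown sit.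

Compound 4 `N#CC1=C(N)Oc2c(c3nc4ccccc4nc3c3ccccc23)C12C(=O)N(Cc1cnnn1-c1cccc(S(N)(=O)=O)c1)c1ccccc12` differs from compound 3 by 3-sulfamoylphenyl in place of 4-acetamidophenyl on an aromatic nitrogen. Among the compounds with values here, no measured step bears on this exchange with a readable size, since every comparison among compounds 1, 2 and 3 ends at the limit. Within the data shown here, the only evidence is that three different groups on this aromatic nitrogen all leave the measurement at the limit in this assay. Compound 4 is therefore expected to give 60000 nM, with a range from 15000 nM to 250000 nM. The expected step that the limit leaves unreadable from compound 3 to compound 4 is thus one that is most likely to remain unreadable at the limit.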

Compound 4, half-maximal inhibitory concentration: 21500 nM
For compound 4 the middle estimate is 2.8-fold (0.45 log units) above the measured one; low and high end bracket the measured number.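

In this assay the aromatic nitrogen of the five-membered ring proves able to move the number, for 3-sulfamoylphenyl there gives the first readable steps (an at least 2.3-fold lower number from compound 3 to compound 4 (0.36 log units; beyond the scatter)) and (an at least 2.3-fold lower number from compound 2 to compound 4 (0.36 log units; beyond the scatter)), and the exchange of sulfamoyl for chloro on an aromatic carbon gives (an at least 2.3-fold lower number from compound 1 to compound 4 (0.36 log units; beyond the scatter)). These steps give only a minimum size, and the steps among compounds 1, 2 and 3 cannot be read, because those compounds stay at the limit: (the limit of > 50000 nM in this assay, at which 3 of the 4 values shown sit). The leaving 4-acetamidophenyl and the entering 3-sulfamoylphenyl have the same heavy-atom count, so an exchange that keeps this count is enough to bring the number off the limit.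

As far as these compounds go, it remains open whether the step belongs to the sulfamoyl group itself or to its place on the phenyl ring, as sulfamoyl appears only in 3-sulfamoylphenyl. Also open, from the compounds shown here alone, is how a carboxylic acid or an amine on that phenyl ring would read.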